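The compounds below may be only part of what the source reports. "The series", "measured", "known", "first", "only" and "open" are said of these compounds alone.

Measured compounds:
- Compound 1, `Cc1nn(C)c(Oc2ccccc2)c1/C=N/OCc1ccc([N+](=O)[O-])cc1`, gives -2.8% in a functional assay on HepG2 cells (Homo sapiens) for antiproliferative activity, tested at 1 uM; a lower number here means less inhibition, a higher number more inhibition at the concentration tested (going by the name of the read-out).
- Compound 2, `Cc1ccc(CO/N=C/c2c(C)nn(C)c2Oc2ccccc2)cc1`, gives 8.4% in this assay.

Going by the values given here, compound 2 stands highest of the two numbers measured so far; its only neighbour is compound 1, and the gap between them is beyond the scatter. The unmeasured compound 3, `Cc1nn(C)c(Oc2ccccc2)c1/C=N/OCc1ccc(C(F)(F)F)cc1`, differs from compound 2 in one place: trifluoromethyl in place of methyl on an aromatic carbon.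

Among the compounds with values here, no measured step swaps methyl for trifluoromethyl, so none bears on this change directly. Within the data shown here, the single step available, a number 11.2 percentage points higher from compound 1 to compound 2 (beyond the scatter), shows that exchanging the group on this aromatic carbon can move the number modestly in either sense. That is thin ground. With no closer comparison, the expectation for compound 3 is a number near that of compound 2, with a step of a number 3.4 percentage points lower from compound 2 to compound 3 (within the scatter) that stays within the scatter. Compound 3 is therefore estimated at 5%, with a range from -10% to 20%, wide enough to allow a small drop toward compound 1 as well as a small rise.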

Compound 3, a percentage reported as inhibition, at one concentration (the size of the read-out at that concentration, not a potency): 5.8%
Compound 3: middle estimate off by 0.8 percentage points, on the low side; the measured number falls inside the stated range.
By their numbers in this assay, from the lowest: compounds 1, 3 and 2 (each within the scatter of the next, the first and the last beyond it).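

Swapping methyl for trifluoromethyl on this aromatic carbon, which takes the group from 1 heavy atom to 4 heavy atoms, gives a number 2.6 percentage points lower from compound 2 to compound 3 (within the scatter) in this assay and so makes no difference that this read-out can resolve. Trifluoromethyl also cannot be told apart from nitro, with a number 8.6 percentage points higher from compound 1 to compound 3 (within the scatter) even though nitro and methyl are separated by a number 11.2 percentage points higher from compound 1 to compound 2 (beyond the scatter) and this makes that single gap a narrow one, since a third group now fits with both of its ends. No other measurement here bears on this result.

Going by these compounds, all three compounds share the same core and differ only in this one group, so the effect of an amine, a carboxylic acid or a longer chain such as butyl on this carbon stays open, as does any change elsewhere on the core. The numbers also come from a single concentration, so they give the size of the inhibition there and leave open how these compounds would behave at higher concentrations.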